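A tert-butylphenyl in place of fluorophenyl on compound 2

A few compounds are considered here, and "the series" means these few. Any claim that something is new, unique, unknown or untested is made for them only; others in the source may bear on it.

In a functional assay on cells (T-cell, Homo sapiens) for inhibition (a lower number here means a stronger inhibitor, a higher number a weaker inhibitor), compound 1 `COc1ccc(-c2cnc3nc(N)nc(NCc4ccccc4)c3n2)cc1OC` gives 13000 nM. Compound 2 `COc1ccc(-c2cnc3nc(N)nc(N4CCN(Cc5ccccc5F)CC4)c3n2)cc1OC`, which carries the same pair of methoxy groups and the same shared core but differs at the amine side, gives 700 nM in this assay. Compound 3 `CC(C)Oc1nc(N)nc2ncc(-c3ccc(C(F)(F)F)cc3)nc12` is reported only as a limit of this assay, > 10000 nM; this is the limit of > 10000 nM in this assay, at which 1 of the 3 values shown sits. Among the two numbers shown, compound 2 has the lower one, and compound 1 stands clearly higher, beyond the usual scatter of repeated measurements.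

Compound 4 `COc1ccc(-c2cnc3nc(N)nc(N4CCN(Cc5ccc(C(C)(C)C)cc5)CC4)c3n2)cc1OC` has not yet been measured. It differs from compound 2 in one place: 4-(tert-butyl)phenyl in place of 2-fluorophenyl on a saturated chain carbon bound to an amine nitrogen in a ring. Put another way, the same difference, cut one bond further out, reads 2-fluorobenzyl to 4-(tert-butyl)benzyl.

Among the measured compounds shown here, no measured pair in this set reports how such a change affects the number, so the direction of the step is open. The step from compound 2 to compound 4 is expected to be modest, with the estimate leaning slightly toward a higher number, a 1.4-fold higher number from compound 2 to compound 4 (0.15 log units; within the scatter). Compound 4 is therefore expected to give about 1000 nM in this assay, with a range from 200 nM to 5000 nM, given that compound 2 gives 700 nM as its nearest comparison.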

Compound 4, half-maximal inhibitory concentration: 4300 nM
For compound 4 the middle estimate is 4.3-fold (0.63 log units) below the measured one; the measured number falls inside the stated range.
By their numbers in this assay, from the lowest: compound 2; then compound 4; then compound 1.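

In this assay, putting 4-(tert-butyl)phenyl in place of 2-fluorophenyl on a saturated chain carbon bound to an amine nitrogen in a ring gives a 6.1-fold higher number from compound 2 to compound 4 (0.79 log units; beyond the scatter), so the number responds to the group carried at this position. The earlier compounds shown here held no pair differing only here, and since compound 4 keeps the pair of methoxy groups and the shared core of compound 2, this single exchange is the only structural difference behind the step. Nothing measured here bears on what in the exchange accounts for the size of this step.

The exchange alters both the group on the phenyl ring and the place it occupies there, and the compounds shown do not separate these two changes. Going by these compounds, it also stays open whether a plain phenyl, a 4-fluorophenyl, or a phenyl carrying a small amine or a carboxylic acid would hold the number close to that of compound 2 or move it further in this assay.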